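The source may hold more compounds than are shown below. What is called first, only, known or untested is meant among the compounds shown, and "the series" means these compounds.

Working notes on the series. Two analogues of the shared core have been measured: compound 1 `CCCCc1ccc(NS(=O)(=O)c2ccc(N3CCNC3=O)cc2)cc1` and compound 2 `O=C1NCCN1c1ccc(S(=O)(=O)Nc2ccc(F)c(F)c2)cc1`. In a functional assay on M21 cells (Homo sapiens) for antiproliferative activity, read by sulforhodamine B assay, with a stated time of 48 h (a higher number here means a weaker inhibitor, a lower number a stronger inhibitor), compound 1 gives 450 nM, the higher of the two numbers on hand. In this assay compound 2 gives 220 nM, a gap from compound 1 that lies beyond the scatter. Compound 3 `O=C1NCCN1c1ccc(S(=O)(=O)Nc2ccc(OC(F)F)cc2)cc1` is not yet measured; it differs from compound 1 by difluoromethoxy in place of butyl on an aromatic carbon. Going by the values given here, no measured pair covers this change, so the step is expected to be a 1.7-fold lower number from compound 1 to compound 3 (0.24 log units; within the scatter) in this assay, a modest lowering of the number. Compound 3 is estimated at 260 nM in this assay, within 100 nM to 700 nM.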

Compound 3, half-maximal inhibitory concentration: 410 nM
The estimate for compound 3 lay 1.6-fold (0.20 log units) below the measured number; low and high end bracket the measured number.
By their numbers in this assay, from the lowest: compounds 2, 3 and 1 (each within the scatter of the next, the first and the last beyond it).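

Going by these compounds alone, the step at this position in this assay is a 1.1-fold lower number from compound 1 to compound 3 (0.04 log units; within the scatter), the first reading of any change here. Although butyl is all carbon and difluoromethoxy brings oxygen, fluorine and a hydrogen-bond acceptor, compound 1 and compound 3 cannot be told apart in this read-out, so the position accepts both groups. No measurement on hand accounts for this likeness.

Going by these compounds, whether an amine, a carboxylic acid or a longer chain on this aromatic carbon would also stay within the scatter of compound 1 remains open.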